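A few compounds are considered here, and "the series" means these few. Any claim that something is new, unique, unknown or untested is made for them only; others in the source may bear on it.

Series notes. Compound 1 `COc1ccc(C2N=C(SCc3ccc(F)cc3)NC(C)=C2C(=O)Nc2ccc(F)cc2)cc1OC`, compound 2 `CC1=C(C(=O)Nc2ccc([N+](=O)[O-])cc2)C(c2ccc(Br)cc2)N=C(SCc2ccccc2)N1` and compound 3 `CC1=C(C(=O)Nc2ccc([N+](=O)[O-])cc2)C(c2cccc([N+](=O)[O-])c2)N=C(SCc2ccccc2)N1` share one core and have all been run in a functional assay on the whole organism (artery, strain albino) with Rattus norvegicus as the target, with a stated time of 360 min, at a dose of 10 mg/kg by the oral route; on this read-out higher numbers stand for more inhibition at the one dose given (going by the name of the read-out) and lower numbers for less inhibition. In this assay compound 1 gives 37.1%, compound 2 gives 37.6% and compound 3 gives 32.5%. Among the compounds with values here, the one single-site step among them, a number 5.1 percentage points lower from compound 2 to compound 3 (within the scatter), stays within the scatter. Compound 3 thus stands level with both others: its value and that of compound 1 lie within the scatter of each other, as do its value and that of compound 2, so the three numbers give no ordering.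

Compound 4 `CC1=C(C(=O)Nc2ccc([N+](=O)[O-])cc2)C(c2cccc([N+](=O)[O-])c2)N=C(SCc2cccc(Cl)c2)N1` is not yet measured. It differs from compound 3 by chloro in place of hydrogen on an aromatic carbon, the change sitting on the benzylsulfanyl part, which reads as benzylsulfanyl to (3-chlorobenzyl)sulfanyl. Within the data shown here, no measured step touches that part; the only step known alters the group on the saturated ring carbon, and it bears on this change only in showing that one substituent swap elsewhere left this assay unmoved beyond the scatter. With nothing pointing either way, the expected step of a number 0.5 percentage points higher from compound 3 to compound 4 (within the scatter) is none beyond the scatter. For compound 4 the estimate in this assay is 33%, with a range from 22% to 45%.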

Compound 4, a percentage reported as inhibition, in the whole organism at one dose (the size of the read-out at that dose, not a potency): 21.6%
Compound 4: middle estimate off by 11.4 percentage points, on the high side, outside the stated range (below it).
By their numbers in this assay, from the lowest: compound 4; then compounds 3, 1 and 2 (each within the scatter of the next).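

Within the data shown here, the benzylsulfanyl part is not silent in this assay: going to (3-chlorobenzyl)sulfanyl, with chloro in place of hydrogen on an aromatic carbon, gives a number 10.9 percentage points lower from compound 3 to compound 4 (beyond the scatter) and is the first single-site step to pass the scatter, though only modestly. Among these compounds, the one earlier step, a number 5.1 percentage points lower from compound 2 to compound 3 (within the scatter) on the saturated ring carbon, left the number within the scatter, so the series now holds a single-site change that reads as a loss of inhibition at the one dose given, and it comes from one added heavy atom on the benzyl ring. The data at hand offer no explanation for this drop.

As far as these compounds go, whether the loss belongs to chloro itself or to any group on this aromatic carbon remains open, since a single substituent at one place cannot separate the two; a methoxy group, an amine or a carboxylic acid on the same carbon would test this. Also open, from the compounds shown here alone, is whether the same change carries over when the saturated ring carbon bears the 4-bromophenyl group of compound 2 instead of the 3-nitrophenyl group of compound 3.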